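Benzylamino for anilino in a hydroxycarbamoyl series

This account rests on a few compounds, and the source may have more. Where it says the series, first, only, none or still open, it means among the compounds named here.

Within the data shown here, compound 1 `O=C(CCCCCNC(=O)Cn1cnc2c(Nc3ccccc3)ncnc21)NO` is the only member of the series with a numerical result: in a functional assay on MDA-MB-231 cells (Homo sapiens) for inhibition, read by MTT assay, with a stated time of 48 h (on this read-out lower numbers stand for stronger inhibition and higher numbers for weaker inhibition), compound 1 gives 22300 nM. Compound 2 `O=C(CCCCNC(=O)Cn1cnc2c(Nc3ccccc3)ncnc21)NO` reaches only a limit of the assay, > 50000 nM. Among the measured compounds shown here, the step of an at least 2.2-fold higher number from compound 1 to compound 2 (0.35 log units; beyond the scatter) is the one measured step in the set, and it sits at the limit of > 50000 nM in this assay, at which 1 of the 2 values shown sits, so its full size is not known.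

Compound 3 `O=C(CCCCCNC(=O)Cn1cnc2c(NCc3ccccc3)ncnc21)NO` differs from compound 1 in one place: benzyl in place of phenyl on a nitrogen on an aromatic ring. The change is anilino to benzylamino. For the measured compounds named here, no measured step touches this part of the structure; the one step seen concerns the length of the chain and gives no guide to a change on the nitrogen on the aromatic ring. What bears on compound 3 is therefore only where compound 1 stands in this assay, 22300 nM, and no shift beyond the scatter is expected from it. The estimated step of a 1.0-fold lower number from compound 1 to compound 3 (0.01 log units; within the scatter) is expected to stay within the scatter. Compound 3 is estimated at 22000 nM in this assay, between 8000 nM and 60000 nM, with a real chance that only a limit is returned.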

Compound 3, half-maximal inhibitory concentration: 34200 nM
Compound 3: the middle estimate sits 1.6-fold (0.19 log units) below what was measured, within the range that was stated.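

In this assay, among these compounds, the change from anilino to benzylamino is the first one seen on the nitrogen on the aromatic ring, and it reads as a 1.5-fold higher number from compound 1 to compound 3 (0.19 log units; within the scatter). Benzyl and phenyl therefore cannot be told apart at this position in this series, at least on the chain of compound 1, and the series gains a second compound with a numerical result. Compound 3 returns a number and not a limit, so this step can be read in full, whereas the chain step ends at the limit of compound 2: the limit of > 50000 nM in this assay, at which 1 of the 3 values shown sits.

The compounds shown leave open whether a group on this nitrogen that differs more from phenyl and benzyl, such as phenethyl, cyclohexyl or a methoxy-substituted benzyl, would move the number beyond the scatter, and one pair alone cannot show how far the position tolerates change. Also open, on these data alone, are whether a longer chain than that of compound 1 would give a lower number, and whether benzylamino behaves the same way on the shorter chain of compound 2.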